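A few compounds are considered here, and "the series" means these few. Any claim that something is new, unique, unknown or untested is made for them only; others in the source may bear on it.

In an ADME assay on HepG2 cells (Homo sapiens) for cytotoxicity, read by MTT assay, with a stated time of 72 h (on this read-out lower numbers stand for higher toxicity in this test and higher numbers for lower toxicity in this test), compound 1 `CC1(c2ccc(Cl)cc2)CC(S(=O)(=O)c2ccc(F)cc2)=C(c2ccc(/C(N)=N\O)cc2)O1` gives 61400 nM. Compound 2 `CC1(c2ccc(-c3ccncc3)cc2)CC(S(=O)(=O)c2ccc(F)cc2)=C(c2ccc(/C(N)=N\O)cc2)O1` gives 30300 nM in this assay, and the step of a 2.0-fold lower number from compound 1 to compound 2 (0.31 log units; beyond the scatter) is modest. Compound 3 `COc1cc(-c2ccc(C3(C)CC(S(=O)(=O)c4ccc(F)cc4)=C(c4ccc(/C(N)=N\O)cc4)O3)cc2)cc(OC)c1OC` stands in this assay not at a number but at a limit, > 50000 nM, which is the limit of > 50000 nM in this assay, at which 1 of the 3 values shown sits. Because compound 3 sits at that limit, the steps reaching it are only partly readable: a step that the limit leaves unreadable from compound 1 to compound 3, and an at least 1.6-fold higher number from compound 2 to compound 3 (0.21 log units; that floor lies within the scatter). Compound 4 `Cc1ccc(-c2ccc(C3(C)CC(S(=O)(=O)c4ccc(F)cc4)=C(c4ccc(/C(N)=N\O)cc4)O3)cc2)cc1` differs from compound 3 in one place: 4-methylphenyl in place of 3,4,5-trimethoxyphenyl on an aromatic carbon. The exchange is of one aromatic group for another, and the two measured steps that end at compound 3 show that exchanging this group moved the number by little, or by an amount the limit hides. The step of a number no higher from compound 3 to compound 4 (the limit leaves the size open) is therefore expected to be small, with no clear direction beyond the scatter, and compound 4 may again be reported only as a limit. Compound 4 is estimated at 50000 nM, expected to fall between 20000 nM and 150000 nM.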

Compound 4, half-maximal cytotoxic concentration: 13700 nM
Compound 4: middle estimate off by 3.6-fold (0.56 log units), on the high side, and the stated range ends above it.
By their numbers in this assay, from the lowest: compound 4; then compound 2; then compound 1.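

In this assay, placing 4-methylphenyl at this position gives an at least 3.6-fold lower number from compound 3 to compound 4 (0.56 log units; beyond the scatter), along with a 2.2-fold lower number from compound 2 to compound 4 (0.34 log units; beyond the scatter) and a 4.5-fold lower number from compound 1 to compound 4 (0.65 log units; beyond the scatter), so compound 4 has the lowest number of the four compounds and the highest toxicity in this test. Until now, no exchange of one aromatic ring for another had produced a readable step beyond the scatter, but this result shows that the choice of ring at this position can matter. The step from compound 3 still gives only a minimum size, since the value for compound 3 is a limit: the limit of > 50000 nM in this assay, at which 1 of the 4 values shown sits.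

The compounds shown cannot separate the effect of adding the methyl group from that of losing the three methoxy groups. A plain phenyl ring or a 4-methoxyphenyl group at this position would help to tell these two changes apart.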